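The source may report more compounds than this note shows. Statements on the series, on what has been measured and on what is new or still open speak of the compounds shown alone.

Measured compounds in a functional assay on HGC-27 cells (Homo sapiens) for cytotoxicity, read by MTT assay, with a stated time of 72 h; on this read-out higher numbers stand for weaker inhibition and lower numbers for stronger inhibition:
Compound 1, `FC(F)(F)c1ccc(CSc2nc(Nc3ccccc3)c3ccccc3n2)cc1`, gives 26400 nM.
Compound 2, `FC(F)(F)c1ccc(CSc2nc(Nc3ccccc3Cl)c3ccccc3n2)cc1`, gives only a limit, > 50000 nM.
Compound 3, `FC(F)(F)c1ccc(CSc2nc(Nc3ccc(C(F)(F)F)cc3)c3ccccc3n2)cc1`, gives 7560 nM.

Compound 2 stands at the floor of the series: its result is a limit, not a number, namely (the limit of > 50000 nM in this assay, at which 1 of the 3 values shown sits). The step of an at least 1.8-fold higher number from compound 1 to compound 2 (0.27 log units; that floor lies within the scatter) therefore has only a floor, and that floor lies within the scatter. The step of a 3.5-fold lower number from compound 1 to compound 3 (0.54 log units; beyond the scatter) is modest but beyond the scatter, and the step of an at least 6.6-fold lower number from compound 2 to compound 3 (0.82 log units; beyond the scatter) is at least modest.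

Compound 4, `COc1ccc(Nc2nc(SCc3ccc(C(F)(F)F)cc3)nc3ccccc23)cc1`, is to be measured in this assay. The change from compound 2 is 4-methoxyphenyl in place of 2-chlorophenyl on a nitrogen on an aromatic ring. Within the data shown here, the one measured step that bears on it is the one from compound 2 to compound 3, which also removes the 2-chlorophenyl and lowers the number at least modestly. Among the measured compounds shown here, no measured compound carries a 4-methoxyphenyl, so the size of the effect of that group itself is unknown; the expectation rests on leaving the 2-chlorophenyl, which in compound 3 gave 7560 nM. A step of an at least 2.5-fold lower number from compound 2 to compound 4 (0.39 log units; beyond the scatter) is expected, toward a number near that of compound 1. Compound 4 is estimated at 20000 nM, with a range from 6000 nM to 60000 nM.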

Compound 4, half-maximal inhibitory concentration: 23500 nM
Compound 4: middle estimate off by 1.2-fold (0.07 log units), on the low side; low and high end bracket the measured number.
By their numbers in this assay, from the lowest: compound 3; then compounds 4 and 1 (each within the scatter of the next). At a limit, above all of these: compound 2.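

In this assay the change to 4-methoxyphenyl gives an at least 2.1-fold lower number from compound 2 to compound 4 (0.32 log units; beyond the scatter), so leaving the 2-chlorophenyl is enough to return a measured number, though this step has only a floor, resting on a limit for compound 2: the limit of > 50000 nM in this assay, at which 1 of the 4 values shown sits. Set against hydrogen, methoxy gives a 1.1-fold lower number from compound 1 to compound 4 (0.05 log units; within the scatter) and no change can be claimed from it. Set against trifluoromethyl, methoxy gives a 3.1-fold higher number from compound 3 to compound 4 (0.49 log units; beyond the scatter) and so, among compounds 1, 3 and 4, only the 4-(trifluoromethyl)phenyl stands apart, which means the lower number of compound 3 does not extend to the 4-methoxyphenyl.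

Going by these compounds, how far compound 2 lies past its limit stays open, and with it the full size of the 2-chlorophenyl effect. Also open, on these data alone, is how a 4-chlorophenyl, or a phenyl carrying an amine or a carboxylic acid, would read on this nitrogen.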